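The source may hold more compounds than are shown below. What is called first, only, known or untested is meant among the compounds shown, and "the series" means these compounds.

Compound 1 `CCCC(Oc1ccc(-n2cc(Cl)cn2)cc1)c1ccc(C(=O)NCCC(=O)O)cc1` is the only one of the three measured compounds that gives a number in an ADME assay on microsomes from liver (Homo sapiens) for metabolic stability (on this read-out lower numbers stand for slow clearance and higher numbers for fast clearance), where compound 1 shows 10 mL/min/kg. Compound 2 `CCCC(Oc1ccc(-n2cc(C(=O)N(C)C)cn2)cc1)c1ccc(C(=O)NCCC(=O)O)cc1` returns only a limit of the assay, < 13 mL/min/kg. Compound 3 `CCCC(Oc1ccc(-n2cc(C#N)cn2)cc1)c1ccc(C(=O)NCCC(=O)O)cc1` likewise returns only a limit, < 8 mL/min/kg. Accordingly the step of an at least 1.2-fold lower number from compound 1 to compound 3 (0.09 log units; that floor lies within the scatter), while the step that the limit leaves unreadable from compound 1 to compound 2. Compound 4 `CCCC(Oc1ccc(-n2cc3ccccc3n2)cc1)c1ccc(C(=O)NCCC(=O)O)cc1` differs from compound 1 by 2H-indazol-2-yl in place of 4-chloro-1H-pyrazol-1-yl on an aromatic carbon. Among the measured compounds shown here, the measured steps each changed only a group on the 4-chloro-1H-pyrazol-1-yl; none replaced that whole group, so they bear on this change only loosely, and no step clearly beyond the scatter is expected. The expected step is a 1.5-fold higher number from compound 1 to compound 4 (0.18 log units; within the scatter). Compound 4 is estimated at 15 mL/min/kg, between 7 mL/min/kg and 35 mL/min/kg.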

Compound 4, clearance: 44 mL/min/kg
Estimate against measurement, compound 4: 2.9-fold (0.47 log units) below; the measured number lies above the stated range.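

The earlier steps shown here changed only a group on the pyrazole ring, and they either stayed within the scatter or could not be read. Replacing the whole group shows that this assay responds clearly at this position: 2H-indazol-2-yl, which adds a six-membered aromatic ring of carbon only, gives a 4.4-fold higher number from compound 1 to compound 4 (0.64 log units; beyond the scatter). Against the two compounds that return only limits, the same kind of replacement gives an at least 5.5-fold higher number from compound 3 to compound 4 (0.74 log units; beyond the scatter) and an at least 3.3-fold higher number from compound 2 to compound 4 (0.52 log units; beyond the scatter). Nothing shown explains why the number rises. Going by these compounds, whether an amine or a methoxy group on the 2H-indazol-2-yl would lower the number remains open.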